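Amide aryl swap in a monocyte cytotoxicity series

The source may hold more compounds than are shown below. What is called first, only, known or untested is meant among the compounds shown, and "the series" means these compounds.

Measured compounds (each value is an assay limit, not a number):
compound 1 `COc1ccc(-c2cnc(NC(=O)c3ccccn3)n2C)cc1`: > 100000 nM
compound 2 `COc1ccc(-c2cnc(NC(=O)c3ccc([N+](=O)[O-])cc3)n2C)cc1`: > 100000 nM

Both compounds share the core of compound 1 and differ only in the aromatic group on the amide carbonyl. In a toxicity assay on THP-1 cells (Homo sapiens) for inhibition (a higher number here means that more compound is tolerated, a lower number that less compound is tolerated), compound 1 gives > 100000 nM, a limit of the assay and not a measured number. Compound 2 also reaches only a limit in this assay, at > 100000 nM. Both values sit at the limit of > 100000 nM in this assay, at which 2 of the 2 values shown sit. Compound 1 therefore stands at the tolerated end of everything shown, and nothing separates it from compound 2.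

Compound 3 `COc1ccc(-c2cnc(NC(=O)c3cccc(C#N)c3)n2C)cc1` has not yet been tested. It differs from compound 1 by 3-cyanophenyl in place of pyridin-2-yl on a carbonyl carbon. Within the data shown here, no pair of measured compounds supplies a step in this assay. Because both measured values sit at the limit of > 100000 nM in this assay, at which 2 of the 2 values shown sit, the expected step in this assay is a number no higher from compound 1 to compound 3 (the limit leaves the size open), that is none beyond the scatter. Compound 3 is estimated at 100000 nM, within 50000 nM to 200000 nM, most likely reported again as a limit.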

Compound 3, half-maximal cytotoxic concentration: > 100000 nM
Compound 3 gave a limit, no number (the forecaster's own chance of this, stated with the estimate: 85%); the middle value sits exactly at the limit.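

No step can be read from compound 1 to compound 3 in this assay, because both results are limits of the assay, not numbers: the limit of > 100000 nM in this assay, at which 3 of the 3 values shown sit.

The compounds shown leave open how much of each compound is tolerated past that limit, and whether any aromatic group on the amide carbonyl of the shared core changes the result in this assay.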